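Triazole series: amine exchange on the phenoxyacetate ester

The source may hold more compounds than are shown below. What is called first, only, known or untested is meant among the compounds shown, and "the series" means these compounds.

Measured so far:
compound 1 `CC(C)CCN(C)Cc1cn(C2CCCCC2O)nn1`: 42%
compound 2 `CCOC(=O)C1CCCN(Cc2cn(C3CCCCC3OC(=O)COc3ccccc3)nn2)C1`: 21%

In an assay on nucleic acid for inhibition of Nucleic Acid, read by fluorescence, tested at 100 uM (on this read-out lower numbers stand for less inhibition and higher numbers for more inhibition at the one concentration tested (going by the name of the read-out)), compound 1 gives 42%. In this assay, for the measured compounds named here, compound 2 gives 21%, the lower of the two numbers known, and its gap to compound 1 is beyond the scatter. Compound 3 `CC(C)CCN(C)Cc1cn(C2CCCCC2OC(=O)COc2ccccc2)nn1` has not yet been measured. Against compound 2 it shows (isopentyl(methyl)amino in place of 3-(ethoxycarbonyl)piperidin-1-yl on a saturated chain carbon bound to an aromatic carbon). The ester on the cyclohexyl ring is kept as in compound 2. Going by the values given here, no step between measured compounds of this kind is available, so the size and direction of the change can only be judged from the two values at hand. Compound 1 carries the same isopentyl(methyl)amino group, and the higher reading belongs to compound 1 because it gives 42%; compound 2 with the piperidine ester is the lower one. An upward step is therefore expected, estimated as a number 11 percentage points higher from compound 2 to compound 3 (beyond the scatter), of moderate size and not certain to exceed the scatter. Compound 3 is expected to give 32%, in the range 12% to 52%.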

Compound 3, a percentage reported as inhibition, at one concentration (the size of the read-out at that concentration, not a potency): 59%
Estimate against measurement, compound 3: 27 percentage points below; the measured number lies above the stated range.
By their numbers in this assay, from the lowest: compound 2; then compound 1; then compound 3.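

In this assay, with the ester on the oxygen held constant, isopentyl(methyl)amino in place of 3-(ethoxycarbonyl)piperidin-1-yl on a saturated chain carbon bound to an aromatic carbon gives a number 38 percentage points higher from compound 2 to compound 3 (beyond the scatter) as a large step, so this amine exchange alone shifts the reading strongly. With isopentyl(methyl)amino held constant, (phenoxymethyl)carbonyl in place of hydrogen on an oxygen on a saturated carbon gives a number 17 percentage points higher from compound 1 to compound 3 (beyond the scatter) as a modest step, which shows that the low reading of compound 2 does not follow from this ester in itself, something the earlier pair, differing in two places, could not separate. No measurement available here explains either step.

Going by these compounds, it remains open whether the step from the amine exchange comes from the ring or from the ethoxycarbonyl group, and plain piperidin-1-yl or the piperidine bearing a carboxylic acid in place of the ethyl ester would help to separate the two. On these data alone, it also remains open whether the gain from (phenoxymethyl)carbonyl carries over to other amines, or whether a longer chain than isopentyl on the nitrogen moves the reading further.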